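Amide substituent changes at the shared core, compound 4 outlook

The source may hold more compounds than are shown below. What is called first, only, known or untested is meant among the compounds shown, and "the series" means these compounds.

Measured so far in an in vitro assay on BaF3 cells for displacement of a labelled ligand from C-X-C chemokine receptor type 3 (Homo sapiens); on this read-out higher numbers stand for weaker inhibition and lower numbers for stronger inhibition:
compound 1 `CC[C@H]1CN(c2nc(N)c(C(=O)NC)nc2Cl)CCN1C1CCN(Cc2ccc(Cl)cc2)CC1` gives 0.3 nM
compound 2 `CC[C@H]1CN(c2nc(N)c(C(=O)NCC(C)O)nc2Cl)CCN1C1CCN(Cc2ccc(Cl)cc2)CC1` gives 0.3 nM
compound 3 `CC[C@H]1CN(c2nc(N)c(C(=O)NCC(C)(C)O)nc2Cl)CCN1C1CCN(Cc2ccc(Cl)cc2)CC1` gives 8.4 nM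

Compound 3 holds the highest number of the three, and both of its neighbours lie far from it: a 28-fold higher number from compound 1 to compound 3 (1.45 log units; beyond the scatter), and a 28-fold higher number from compound 2 to compound 3 (1.45 log units; beyond the scatter). By contrast no change at the digits printed from compound 1 to compound 2 (within the scatter).

Compound 4 `CC[C@H]1CN(c2nc(N)c(C(=O)NCCNS(=O)(=O)C(F)(F)F)nc2Cl)CCN1C1CCN(Cc2ccc(Cl)cc2)CC1` is the next member. The change from compound 3 reads: (((trifluoromethyl)sulfonyl)amino)methyl in place of 1-hydroxy-1-methylethyl on a saturated chain carbon bound to an amide-type nitrogen.

Among the compounds with values here, two measured steps bear on this. The step from compound 1 to compound 2 shows that an unbranched hydroxy-bearing chain on this nitrogen leaves this assay unchanged. The step from compound 2 to compound 3 shows that adding a methyl at the oxygen-bearing carbon of that chain costs a large amount. Within the data shown here, compound 4 removes the branched carbon and carries an unbranched chain again, though a longer one with no close analogue measured. The expectation is therefore that compound 4 recovers part of the loss, with a 5.6-fold lower number from compound 3 to compound 4 (0.75 log units; beyond the scatter) expected, but the unmeasured chain type keeps the range wide. Compound 4 is estimated at 1.5 nM, between 0.3 nM and 8 nM.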

Compound 4, half-maximal inhibitory concentration: 0.9 nM
For compound 4 the middle estimate is 1.7-fold (0.22 log units) above the measured one; measured number inside the range.
By their numbers in this assay, from the lowest: compounds 1 and 2 (each within the scatter of the next); then compound 4; then compound 3.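

Replacing 1-hydroxy-1-methylethyl with (((trifluoromethyl)sulfonyl)amino)methyl on a saturated chain carbon bound to an amide-type nitrogen gives, in this assay, a 9.3-fold lower number from compound 3 to compound 4 (0.97 log units; beyond the scatter), so the loss at compound 3 does not extend to every substituent with more heavy atoms at this position. The recovery is partial, with a 3.0-fold higher number from compound 1 to compound 4 (0.48 log units; beyond the scatter) and a 3.0-fold higher number from compound 2 to compound 4 (0.48 log units; beyond the scatter), so this chain is tolerated but does not match the smaller substituents of the two lowest compounds. No measured evidence accounts for either the recovery or the remaining gap.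

The compounds shown leave open whether the trifluoromethyl group, the sulfonyl group or the chain itself sets the number at compound 4. A plain 2-aminoethyl chain, a methanesulfonylamino analogue and a carboxylic acid at the chain end would help separate these parts.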